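This account rests on a few compounds, and the source may have more. Where it says the series, first, only, none or still open, it means among the compounds named here.

The study measured three compounds in a functional assay on RKE cells for antagonist activity at Vasoactive intestinal polypeptide receptor 1 (Rattus norvegicus), read by HTRF and cAMP accumulation, with stated times of 10 min and 30 min; a higher number here means a weaker inhibitor, a lower number a stronger inhibitor. Compound 1 `COc1ccc(-c2cc(C(C)(C)C)cc(C(C)C)c2CO)cc1` gives 1300 nM, compound 2 `Cc1cccc(-c2cc(C(C)(C)C)cc(C(C)C)c2CO)c1` gives 240 nM, and compound 3 `CC(C)CC(=O)Nc1sc2c(c1C#N)CCCC2` gives 1900 nM. Compound 3 thus has the highest of the three numbers; compound 1 lies nearest to it, within the scatter, while compound 2 lies furthest away, beyond it. Compound 4 `N#Cc1c(NC(=O)C2CCCC2)sc2c1CCCC2` differs from compound 3 by cyclopentyl in place of isobutyl on a carbonyl carbon. Among the measured compounds shown here, no comparable step among the measured compounds is available, so the size of the change is open; the writer expects a step in this assay of a 1.3-fold lower number from compound 3 to compound 4 (0.10 log units; within the scatter), that is none beyond the scatter in either direction. Compound 4 is therefore estimated at 1500 nM, with a range from 500 nM to 5000 nM.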

Compound 4, half-maximal inhibitory concentration: 470 nM
Compound 4: the middle estimate sits 3.2-fold (0.50 log units) above what was measured; the measured number lies below the stated range.
By their numbers in this assay, from the lowest: compounds 2 and 4 (each within the scatter of the next); then compounds 1 and 3 (each within the scatter of the next).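

In this assay the change of cyclopentyl in place of isobutyl on a carbonyl carbon gives a 4.0-fold lower number from compound 3 to compound 4 (0.61 log units; beyond the scatter). This is the first single-place step among these compounds, and it shows that the group on this carbonyl carbon can move the number beyond the scatter, with the ring-bearing group giving the lower number. No measurement shown here explains the step.

The pair cannot separate the effect of the ring from that of the added carbon. On these data alone, how cyclopropyl, cyclohexyl or phenyl on this carbonyl carbon would compare remains open.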